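A few compounds are considered here, and "the series" means these few. Any claim that something is new, unique, unknown or untested is made for them only; others in the source may bear on it.

Measured compounds:
Compound 1 `OC[C@H]1O[C@@H](n2cc(F)c3c(-c4ccco4)ncnc32)[C@H](O)[C@@H]1O`: 110 nM
Compound 2 `OC[C@H]1O[C@@H](n2cc(F)c3c(-c4c[nH]cn4)ncnc32)[C@H](O)[C@@H]1O`: > 10000 nM (a limit of the assay, not a number)

For the measured compounds named here, in a functional assay on A549 cells (Homo sapiens), read by sulforhodamine B assay, with a stated time of 5 days (a higher number here means a weaker inhibitor of growth, a lower number a stronger inhibitor of growth), compound 1 gives 110 nM, the only true number so far. The one other result is a limit, held by compound 2. Going by the values given here, the single measured step, an at least 90-fold higher number from compound 1 to compound 2 (1.95 log units; beyond the scatter), shows that the group at this place can matter greatly. On these data alone, its size stays open, as it ends at the limit of > 10000 nM in this assay, at which 1 of the 2 values shown sits.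

Compound 3 `OC[C@H]1O[C@@H](n2cc(F)c3c(-c4ccoc4)ncnc32)[C@H](O)[C@@H]1O` keeps the core of compound 1 and changes only the attachment of the furan: furan-3-yl in place of furan-2-yl on an aromatic carbon. The two have the same atoms, joined differently, and the counted features of the group stay the same. The measured step of an at least 90-fold higher number from compound 1 to compound 2 (1.95 log units; beyond the scatter) exchanged the furan for another ring, whereas compound 3 retains a furan, so that step is a loose warning rather than a guide to size. In this assay the expected outcome is a 1.6-fold higher number from compound 1 to compound 3 (0.21 log units; within the scatter), with a slightly higher number thought likelier than a lower one. Compound 3 is estimated at 180 nM, with an expected range of 50 nM to 800 nM.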

Compound 3, concentration for 50% growth inhibition: 60 nM
The estimate for compound 3 lay 3.0-fold (0.48 log units) above the measured number, within the range that was stated.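

Furan-3-yl and furan-2-yl cannot be told apart at this position in this assay: the step is a 1.8-fold lower number from compound 1 to compound 3 (0.26 log units; within the scatter). The earlier compounds shown here showed only that replacing the furan with 1H-imidazol-4-yl could matter greatly; this result adds that the way the furan is attached, with the same atoms and the same counted features, makes no difference beyond the scatter in this assay. On these data alone, the contrast with the imidazole also holds from the other furan, in an at least 160-fold lower number from compound 2 to compound 3 (2.22 log units; beyond the scatter), but its true size remains open, since the value of compound 2 is a limit of the assay and not a number: the limit of > 10000 nM in this assay, at which 1 of the 3 values shown sits.

With only two furans and one imidazole shown, it remains unknown whether the large step belongs to the imidazole alone or would also appear with other rings, such as thiophen-2-yl, thiophen-3-yl, phenyl or pyridin-3-yl. Nor do these compounds tell how a group without a ring, such as an amine or a longer alkyl chain, would fare on this aromatic carbon, or whether substituents on the furan itself would be accepted.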